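Taking one methyl away from compound 3

The source may hold more compounds than are shown below. What is called first, only, known or untested is meant among the compounds shown, and "the series" means these compounds.

Going by the values given here, compound 3 `COc1ccc(Cl)cc1C(C)NC(=O)N(C)S(=O)(=O)c1ccc(C)cc1` is the only compound with an actual number in a functional assay on thoracic aorta (Rattus norvegicus, strain Wistar), with a stated time of 15 min (on this read-out higher numbers stand for an effect only at larger amounts of compound and lower numbers for an effect already at smaller amounts), where compound 3 gives 13800 nM. Compound 1 `COc1ccc(Br)cc1C(C)NC(=O)NS(=O)(=O)c1ccc(C)cc1` reaches only a limit, > 300000 nM. Compound 2 `COc1ccc(Cl)cc1C(C)NC(=O)NS(=O)(=O)c1ccccc1` likewise reaches only a limit, > 300000 nM. Compound 4 `COc1ccc(Cl)cc1C(C)NC(=O)NS(=O)(=O)c1ccc(C)cc1` has not yet been measured in this assay. Its structure departs from compound 3 by hydrogen in place of methyl on an amide-type nitrogen. Compound 1 and compound 2 also carry that hydrogen, and both end at the limit of > 300000 nM in this assay, at which 2 of the 3 values shown sit. The expected step of an 18-fold higher number from compound 3 to compound 4 (1.26 log units; beyond the scatter) therefore lies well beyond the usual scatter, towards an effect only at larger amounts. For compound 4 the estimated value is 250000 nM, with an expected range from 60000 nM to 800000 nM.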

Compound 4, half-maximal effective concentration: > 300000 nM
Compound 4 ended at the assay's limit (the forecaster's own chance of this, stated with the estimate: 70%); middle value at least 1.2-fold (0.07 log units) from the limit.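

In this assay, the methyl on the amide-type nitrogen whose other neighbours are the carbonyl carbon and the sulfonyl sulfur can now be read as a single change: hydrogen in its place gives an at least 21-fold higher number from compound 3 to compound 4 (1.33 log units; beyond the scatter). Compound 1 and compound 2 carried that hydrogen but also differed from compound 3 elsewhere, so they could not isolate it. The steps from them to compound 4 cannot be read, and the compounds with that hydrogen all stop at one limit: the limit of > 300000 nM in this assay, at which 3 of the 4 values shown sit.

On these data alone, whether an ethyl group or a longer chain on that nitrogen would give a lower number than methyl remains open.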